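Second Methoxy on the Hydrazone Aryl Ring

The source may hold more compounds than are shown below. What is called first, only, known or untested is meant among the compounds shown, and "the series" means these compounds.

Compound 3 `COc1ccc(/C=N/NC(=O)c2cccnc2Nc2cccc(C(F)(F)F)c2)cc1` stands lowest of the three measured compounds in a functional assay on the whole organism (strain Wistar) for inhibition, with Rattus norvegicus as the target, read by paw edema, with a stated time of 2 h, at a dose of 10 mg/kg by the intraperitoneal route (a lower number here means less inhibition, a higher number more inhibition at the dose given (going by the name of the read-out)), where compound 3 gives 42.4%. Its nearest neighbour is compound 1 `O=C(N/N=C/c1cccc(F)c1)c1cccnc1Nc1cccc(C(F)(F)F)c1`, which in this assay gives 52.8%, and the furthest is compound 2 `O=C(N/N=C/c1ccc(O)cc1)c1cccnc1Nc1cccc(C(F)(F)F)c1`, which in this assay gives 68%. All measured steps run through the group on the carbon with a double bond to nitrogen: a number 15.2 percentage points higher from compound 1 to compound 2 (beyond the scatter), a number 10.4 percentage points lower from compound 1 to compound 3 (beyond the scatter), and a number 25.6 percentage points lower from compound 2 to compound 3 (beyond the scatter).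

Compound 4 `COc1ccc(/C=N/NC(=O)c2cccnc2Nc2cccc(C(F)(F)F)c2)c(OC)c1` differs from compound 3 by methoxy in place of hydrogen on an aromatic carbon; cut one bond further out, the change reads 4-methoxyphenyl to 2,4-dimethoxyphenyl, the new group sitting ortho to a large group and meta to a methoxy group. Going by the values given here, no measured step adds a second methoxy, so none bears directly on this one; the three steps that exist were all modest, and the two that introduced a methoxy pointed downward. The expectation for compound 4 in this assay is therefore 40%, within 25% to 55%. The step this estimate implies, a number 2.4 percentage points lower from compound 3 to compound 4 (within the scatter), is expected to lie close to the scatter.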

Compound 4, a percentage reported as inhibition, in the whole organism at one dose (the size of the read-out at that dose, not a potency): 44.7%
Estimate against measurement, compound 4: 4.7 percentage points below; the range from low to high includes it.
By their numbers in this assay, from the lowest: compounds 3, 4 and 1 (each within the scatter of the next, the first and the last beyond it); then compound 2.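

In this assay this position, ortho to a large group and meta to a methoxy group, takes a methoxy in place of hydrogen with a number 2.3 percentage points higher from compound 3 to compound 4 (within the scatter), so the second methoxy leaves the read-out where the first one put it. The gap to the 4-hydroxyphenyl compound remains, at a number 23.3 percentage points lower from compound 2 to compound 4 (beyond the scatter), and a free hydroxy on the ring thus still stands apart from both methoxy-bearing compounds. Against the 3-fluorophenyl compound the step is a number 8.1 percentage points lower from compound 1 to compound 4 (within the scatter), whereas compound 3 lay beyond the scatter of compound 1.

No measurement available here explains why the added methoxy leaves so little trace. On these data alone, whether an amine, a carboxylic acid or a longer chain such as ethoxy at this same ring carbon would read any differently remains open.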